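The compounds below may be only part of what the source reports. "The series", "measured", "known", "first", "only" and "open" are said of these compounds alone.

Measured compounds:
- compound 1, `Cc1ccc(NC(=S)Nc2nc[nH]n2)cc1`: 59000 nM
- compound 2, `S=C(Nc1cccc(Br)c1)Nc1nc[nH]n1`: 50000 nM

In an ADME assay on MT4 cells (Homo sapiens) for cytotoxicity, read by MTT assay, with a stated time of 96 h (a lower number here means that less compound is tolerated, a higher number that more compound is tolerated), compound 1 gives 59000 nM, the higher of the two numbers recorded, while compound 2 gives 50000 nM; the gap between them is within the scatter, so the two compounds cannot be told apart in how much of them the cells tolerate.

Compound 3, `S=C(Nc1ccc(Cl)cc1)Nc1nc[nH]n1`, has not yet been measured. It differs from compound 1 by a single change: chloro in place of methyl on an aromatic carbon. For the measured compounds named here, no measured pair shows what this exchange does to this assay. Both measured compounds sit close together, so compound 3 is expected to stay near them, and the step of a 1.1-fold lower number from compound 1 to compound 3 (0.05 log units; within the scatter) is estimated to fall within the scatter in either direction. Compound 3 is therefore expected to give about 52000 nM, with a range from 25000 nM to 105000 nM.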

Compound 3, half-maximal cytotoxic concentration: 47000 nM
Compound 3: middle estimate off by 1.1-fold (0.04 log units), on the high side; the measured number falls inside the stated range.
By their numbers in this assay, from the lowest: compounds 3, 2 and 1 (each within the scatter of the next).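

In this assay, for the compounds shown here, the exchange of methyl for chloro on an aromatic carbon, para to a group of 9 heavy atoms, is the first single change that can be read, and it gives a 1.3-fold lower number from compound 1 to compound 3 (0.10 log units; within the scatter). At this position, then, the two groups cannot be told apart by how much compound the cells tolerate. No measurement at hand offers an explanation for this result.

The compounds shown leave open whether a different kind of group at this position, such as an amine, a carboxylic acid or a longer chain, would also stay within the scatter of compound 1. A single exchange at a single position also cannot show whether the same swap would behave alike elsewhere on the ring or on another core.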